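The compounds below may be only part of what the source reports. "The series", "measured", "known", "first", "only" and "open" are said of these compounds alone.

Measured in an assay on isolated protein for inhibition of Ephrin type-A receptor 2 (Homo sapiens), read by thermal shift assay, tested at 10 uM; on this read-out lower numbers stand for weaker stabilisation of the target and higher numbers for stronger stabilisation of the target against heat:
- compound 1, `Cn1nc(C(C)(C)C)cc1NC(=O)Nc1cc(C(F)(F)F)cc(C(F)(F)F)c1`: 0.4 degrees C
- compound 2, `CC(C)(C)c1cc(NC(=O)Nc2cc(C(F)(F)F)cc(C(F)(F)F)c2)n(-c2ccc(F)cc2)n1`: 0.4 degrees C
- compound 3, `Cn1nc(C(C)(C)C)cc1NC(=O)Nc1cc(F)cc(F)c1`: 0.4 degrees C

Compound 1 and compound 2 differ by one change, (4-fluorophenyl in place of methyl on an aromatic nitrogen), and in this assay that change gave no change at the digits printed from compound 1 to compound 2 (within the scatter). Compound 3 carries a different core; the difference between the core of compound 1 and the core of compound 3 is not broken down here. In this assay compound 3 stands level with compound 1 and compound 2, within the scatter.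

Compound 4, `CC(C)(C)c1cc(NC(=O)Nc2cc(F)cc(F)c2)n(-c2ccc(F)cc2)n1`, is not yet measured. It differs from compound 3 by 4-fluorophenyl in place of methyl on an aromatic nitrogen, the same change as from compound 1 to compound 2, at a place described in identical words. Given that only one precedent exists, the step is expected to be no change at the digits printed from compound 3 to compound 4 (within the scatter), set beside no change at the digits printed from compound 1 to compound 2 (within the scatter). Compound 4 is therefore estimated at 0.4 degrees C, with a range of -0.6 degrees C to 1.4 degrees C, resting on the absence of any step beyond the scatter among compound 1, compound 2 and compound 3.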

Compound 4, shift of the target's melting temperature: 1.9 degrees C
Beside the measured number, compound 4's estimate is 1.5 degrees C below it, and the stated range ends below it.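

In this assay, 4-fluorophenyl in place of methyl on an aromatic nitrogen gives a number 1.5 degrees C higher from compound 3 to compound 4 (beyond the scatter) as a modest step on this core. Two cores do not show which part of the difference between them goes with the unequal result, nor how the change would behave on a third core. The change therefore does not carry unaltered from the core of compound 1 to the core of compound 3: the same change on two cores in this assay, no change at the digits printed (within the scatter) from compound 1 to compound 2 and a number 1.5 degrees C higher (beyond the scatter) from compound 3 to compound 4, 1.5 degrees C apart, beyond the scatter of two such steps

Still open, on these data alone, is whether the step on the core of compound 3 extends to other groups on that aromatic nitrogen, such as unsubstituted phenyl or a longer alkyl chain. Also open, as far as these compounds go, is how an amine or a carboxylic acid in place of the tert-butyl group would read in this assay on either core.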